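A few compounds are considered here, and "the series" means these few. Any claim that something is new, unique, unknown or untested is made for them only; others in the source may bear on it.

Within the data shown here, compound 2 `CCc1ccc2oc(-c3ccc(NC(=O)Nc4cccc(Cl)c4)cc3Cl)cc(=O)c2c1` gives 18% in an ADME assay on QSG7701 cells (Homo sapiens) for inhibition, read by MTT assay, with a stated time of 48 h, tested at 100 uM (on this read-out higher numbers stand for a stronger effect at the one concentration tested and lower numbers for a weaker effect), the lowest of the three numbers measured so far; compound 3 `COc1ccc2oc(-c3ccc(NC(=O)Nc4cccc(Cl)c4)cc3Cl)cc(=O)c2c1` gives 30.1% and compound 1 `O=C(Nc1cccc(Cl)c1)Nc1ccc(-c2cc(=O)c3ccccc3o2)c(Cl)c1` gives 62.4%. The three known steps, a number 44.4 percentage points lower from compound 1 to compound 2 (beyond the scatter), a number 32.3 percentage points lower from compound 1 to compound 3 (beyond the scatter) and a number 12.1 percentage points higher from compound 2 to compound 3 (beyond the scatter), all concern a group on an aromatic carbon of the shared core. Compound 4 `CCc1ccc2oc(-c3ccc(NC(=O)Nc4ccc(Cl)cc4)cc3Cl)cc(=O)c2c1` differs from compound 2 elsewhere: 4-chlorophenyl in place of 3-chlorophenyl on an amide-type nitrogen. Among the measured compounds shown here, no measured step bears on a change at the amide-type nitrogen, so the data give no direction for it, and a step within the scatter is the plain expectation. Compound 4 is therefore expected near 20%, with a range from 5% to 38%. The expected step is a number 2 percentage points higher from compound 2 to compound 4 (within the scatter).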

Compound 4, a percentage reported as inhibition, at one concentration (the size of the read-out at that concentration, not a potency): 31.8%
Compound 4: the middle estimate sits 11.8 percentage points below what was measured; low and high end bracket the measured number.
By their numbers in this assay, from the lowest: compound 2; then compounds 3 and 4 (each within the scatter of the next); then compound 1.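

In this assay, the amide-type nitrogen turns out to be a position that responds: 4-chlorophenyl in place of 3-chlorophenyl gives a number 13.8 percentage points higher from compound 2 to compound 4 (beyond the scatter), although the two compounds have the same atoms. Among these compounds, the earlier steps concerned only a group on an aromatic carbon of the shared core, so this is the first change read at this nitrogen. Nothing available explains the step.

Going by these compounds, this step is read only with the ethyl group on the core, so its size with hydrogen or methoxy there remains open. Also open, on these data alone, is how an unsubstituted phenyl or a methoxyphenyl on this nitrogen would compare.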